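Phenethyl for phenoxy on the core of compound 1

The source may hold more compounds than are shown below. What is called first, only, known or untested is meant among the compounds shown, and "the series" means these compounds.

Among the compounds with values here, compound 1 `c1ccc(Oc2ccc3c(NCCCNCc4ccco4)ccnc3c2)cc1` is one of three compounds measured in a physicochemical assay for solubility, with a stated time of 18 h, at pH 7.4; a higher number here means a more soluble compound, a lower number a less soluble compound. In this assay compound 1 gives 14500 nM. Compound 2 `COc1cccc(CNCCCNc2ccnc3cc(Oc4ccccc4)ccc23)c1O` gives 14500 nM, and compound 3 `COc1cccc(CNCCCNc2ccnc3cc(Oc4cccc(N(C)C)c4)ccc23)c1O` gives 14500 nM, so compound 1 stands level with both on the digits shown. The two measured steps, no change at the digits printed from compound 1 to compound 2 (within the scatter) and no change at the digits printed from compound 2 to compound 3 (within the scatter), both alter the chain end or a distant aromatic carbon, not the phenoxy group.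

The unmeasured compound 4 `c1ccc(CCc2ccc3c(NCCCNCc4ccco4)ccnc3c2)cc1` is reached from compound 1 by the change (phenethyl in place of phenoxy on an aromatic carbon). Within the data shown here, no measured step touches this position or this group, so the three measured compounds offer no direct guide; they show only that the shared core has given the same solubility under each variation tried so far. The account therefore expects a step from compound 1 to compound 4 of about a 1.5-fold lower number from compound 1 to compound 4 (0.16 log units; within the scatter), close to or within the scatter. Compound 4 is estimated at 10000 nM, with a range from 3500 nM to 20000 nM.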

Compound 4, solubility: 4200 nM
Estimate against measurement, compound 4: 2.4-fold (0.38 log units) above; the measured number falls inside the stated range.
By their numbers in this assay, from the lowest: compound 4; then compounds 1, 2 and 3 (each within the scatter of the next).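

In this assay, this position is the first place shown where a single change moves the number beyond the scatter: the replacement of phenoxy by phenethyl gives a 3.5-fold lower number from compound 1 to compound 4 (0.54 log units; beyond the scatter), whereas the earlier steps gave no change at the digits printed from compound 1 to compound 2 (within the scatter) and no change at the digits printed from compound 2 to compound 3 (within the scatter), both at other places. The level values of the first three compounds therefore do not extend to every change on the shared core, and this one exchanges an oxygen-linked group carrying a hydrogen-bond acceptor for an all-carbon group with none. No measurement shown bears on the reason for this drop.

As far as these compounds go, whether the step follows the loss of the oxygen or the different link stays open, and a phenylamino, phenylthio or benzyl group on this aromatic carbon would bear on that. From the compounds shown here alone, it is also open whether phenethyl gives a similar step with the 2-hydroxy-3-methoxyphenyl chain end of compound 2.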